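Working notes on compounds 1 to 4 in the cytotoxicity series

The source may report more compounds than this note shows. Statements on the series, on what has been measured and on what is new or still open speak of the compounds shown alone.

Compound 1 `COc1ccc(C(=O)c2cc(OC)c(OC)c(OC)c2)cc1NC(=O)/C=C/c1cc(OC)c(OC)c(OC)c1`: 6300 nM in a functional assay on DU-145 cells (Homo sapiens) for cytotoxicity, read by MTT assay, with a stated time of 72 h; on this read-out lower numbers stand for stronger inhibition and higher numbers for weaker inhibition
Compound 2 `COc1cccc(/C=C/C(=O)Nc2cc(C(=O)c3cc(OC)c(OC)c(OC)c3)cc(OC)c2OC)c1`: 12500 nM in this assay
Compound 3 `COc1ccc(/C=C/C(=O)Nc2cc(C(=O)c3cc(OC)c(OC)c(OC)c3)cc(OC)c2OC)cc1N`: 12700 nM in this assay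

Compound 3 stands at the highest of the three numbers, yet all three lie within the scatter of each other: the step of a 1.0-fold higher number from compound 2 to compound 3 (0.01 log units; within the scatter) is within the scatter, and compounds 1 and 3 differ by no more than the scatter either. Compound 4 `COc1cc(C(=O)c2cc(OC)c(OC)c(OC)c2)cc(NC(=O)/C=C/c2cc(F)c(F)c(F)c2)c1OC` differs from compound 3 by 3,4,5-trifluorophenyl in place of 3-amino-4-methoxyphenyl on a double-bonded chain carbon bound to a double-bonded chain carbon. Among the measured compounds shown here, the only measured step at this place, a 1.0-fold higher number from compound 2 to compound 3 (0.01 log units; within the scatter), changed nothing beyond the scatter, so compound 4 is expected to show a step of about a 1.2-fold lower number from compound 3 to compound 4 (0.06 log units; within the scatter) in this assay, not beyond the scatter. Compound 4 is therefore estimated at 11000 nM, with a range from 3500 nM to 35000 nM.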

Compound 4, half-maximal inhibitory concentration: 7900 nM
Compound 4: the middle estimate sits 1.4-fold (0.14 log units) above what was measured; measured number inside the range.
By their numbers in this assay, from the lowest: compounds 1, 4, 2 and 3 (each within the scatter of the next).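

At this place, on a double-bonded chain carbon bound to a double-bonded chain carbon, a ring with 0 hydrogen-bond donors and 0 hydrogen-bond acceptors now stands in the series. In this assay, 3,4,5-trifluorophenyl in place of 3-amino-4-methoxyphenyl gives a 1.6-fold lower number from compound 3 to compound 4 (0.21 log units; within the scatter), and 3,4,5-trifluorophenyl in place of 3-methoxyphenyl gives a 1.6-fold lower number from compound 2 to compound 4 (0.20 log units; within the scatter), so losing these donors and acceptors leaves the number within the scatter. No supporting data bear on these steps. Every step at this place remains within the scatter, so what this position can do stays undefined. Going by these compounds, whether a carboxylic acid or a longer chain here would move the number beyond the scatter remains open.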